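Cytotoxicity notes: amide variation on the shared core

The compounds below may be only part of what the source reports. "The series", "measured", "known", "first", "only" and "open" are said of these compounds alone.

Compounds measured so far in a toxicity assay on THP-1 cells (Homo sapiens) for inhibition; on this read-out higher numbers stand for lower toxicity in this test and lower numbers for higher toxicity in this test:
- compound 1, `COc1ccc(-c2cnc(NC(=O)c3ccccc3F)n2C)cc1`
- compound 2, `COc1ccc(-c2cnc(NC(=O)CCc3ccccc3)n2C)cc1`
- compound 3, `COc1ccc(-c2cnc(NC(=O)c3ccc(Cl)cc3)n2C)cc1`

In this assay compound 1 reaches only the limit > 100000 nM. In this assay compound 2 likewise gives the limit > 100000 nM. In this assay compound 3 also stops at the limit > 100000 nM. The three steps among them, a step that the two limits leave unreadable from compound 1 to compound 2, a step that the two limits leave unreadable from compound 1 to compound 3 and a step that the two limits leave unreadable from compound 2 to compound 3, therefore carry no readable size; all that can be said is the limit of > 100000 nM in this assay, at which 3 of the 3 values shown sit.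

Compound 4, `COc1ccc(-c2cnc(NC(=O)c3ccc(C#N)cc3)n2C)cc1`, has not yet been measured. It differs from compound 3 by cyano in place of chloro on an aromatic carbon. For the measured compounds named here, no measured step gives a readable size for any change of the amide substituent on this core, and all three compounds stand at the same limit. The expected step that the limit leaves unreadable from compound 3 to compound 4 is accordingly none beyond the scatter, with compound 4 most likely also reported only as a limit. Compound 4 is estimated at 150000 nM, within 50000 nM to 400000 nM.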

Compound 4, half-maximal cytotoxic concentration: > 100000 nM
Compound 4 ended at the assay's limit; the forecaster's own chance of this, stated with the estimate: 85%; the middle value does not contradict the limit.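

In this assay compound 4 gives > 100000 nM, which is a limit and not a number. The steps from compound 1, compound 2 and compound 3 to compound 4 therefore cannot be read: the limit of > 100000 nM in this assay, at which 4 of the 4 values shown sit.

The compounds shown leave open whether any amide substituent on the shared core gives a measurable cytotoxic concentration.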